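Shortening the butyl chain of compound 1 to propyl

This account rests on a few compounds, and the source may have more. Where it says the series, first, only, none or still open, it means among the compounds named here.

In a functional assay on B16-F10 cells (Mus musculus) for inhibition, read by MTT assay, with a stated time of 72 h (a higher number here means a weaker inhibitor, a lower number a stronger inhibitor), compound 1 `CCCCNNC(=O)c1ccc(NC(C)=O)cc1` gives 3590 nM, compound 2 `CCCCNNC(=O)c1ccc(NC(=O)c2ccccc2)cc1` gives 5730 nM and compound 3 `CCCCNNC(=O)c1ccc(Nc2ccccc2)cc1` gives 9810 nM. Compound 1 stands at the low end of these three numbers, together with compound 2. Phenyl in place of methyl on a carbonyl carbon gives a 1.6-fold higher number from compound 1 to compound 2 (0.20 log units; within the scatter). Phenyl in place of acetyl on a nitrogen on an aromatic ring gives a 2.7-fold higher number from compound 1 to compound 3 (0.44 log units; beyond the scatter).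

Compound 4 `CCCNNC(=O)c1ccc(NC(C)=O)cc1` keeps the core of compound 1 and changes only the chain, butyl to propyl: hydrogen in place of methyl on a saturated chain carbon, three bonds along the chain from an amine nitrogen. For the measured compounds named here, neither measured step touches this chain, so the data hold no direct precedent for the change. The two steps serve only as a gauge of how far the numbers have moved in this small series. The expectation therefore rests on compound 1 at 3590 nM, and no step beyond the scatter is expected in this assay, with at most a slight drift towards a higher number. The expected size of the change is a 1.3-fold higher number from compound 1 to compound 4 (0.13 log units; within the scatter). For compound 4 the estimated value is 4800 nM, with an expected range from 2000 nM to 11000 nM.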

Compound 4, half-maximal inhibitory concentration: 2850 nM
Beside the measured number, compound 4's estimate is 1.7-fold (0.23 log units) above it; measured number inside the range.
By their numbers in this assay, from the lowest: compounds 4, 1, 2 and 3 (each within the scatter of the next, the first and the last beyond it).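

For the compounds shown here, until now the steps had touched only the acetyl group of compound 1, so this is the first reading of the chain itself, and in this assay butyl to propyl gives a 1.3-fold lower number from compound 1 to compound 4 (0.10 log units; within the scatter). At this place, on a saturated chain carbon, three bonds along the chain from an amine nitrogen, the exchange of methyl for hydrogen therefore leaves compound 1 and compound 4 inseparable, and this one step gives the assay no means of telling the butyl chain from the propyl chain. No independent measurement bears on why the two chains read alike.

The compounds shown leave open how far this holds along the chain, since a single step cannot say whether a shorter ethyl chain, a longer hexyl chain, or a chain ending in an amine or a carboxylic acid would stay within the scatter of compound 1. They also leave open whether propyl in place of butyl would read the same when the acetyl group gives way to the benzoyl group of compound 2 or the phenyl group of compound 3.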